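The source may hold more compounds than are shown below. What is called first, only, known or untested is meant among the compounds shown, and "the series" means these compounds.

Measured so far in a functional assay on U-373MG ATCC cells (Homo sapiens) for inhibition, read by MTT assay, with a stated time of 72 h; a higher number here means a weaker inhibitor, a lower number a stronger inhibitor:
Compound 1 `COc1ccc(NC(=S)NC2CC(C)(C)Oc3ccc(Br)cc32)cc1` gives 40000 nM
Compound 2 `CC1(C)CC(NC(=S)Nc2cccc(C#N)c2)c2cc(Br)ccc2O1` gives 6000 nM

Of these two, compound 1 holds the higher number, 40000 nM, and so is the weaker inhibitor. Compound 3 `CC1(C)CC(NC(=S)Nc2ccc([N+](=O)[O-])cc2)c2cc(Br)ccc2O1` differs from it by nitro in place of methoxy on an aromatic carbon in one place: nitro in place of methoxy on an aromatic carbon, para to a large group. Among the measured compounds shown here, the only measured step bearing on this is a 6.7-fold lower number from compound 1 to compound 2 (0.82 log units; beyond the scatter), where 3-cyanophenyl replaces 4-methoxyphenyl. A lower number of similar size is therefore expected in this assay, though a single step gives thin support. The expected value for compound 3 is 8000 nM, with an estimated range from 2500 nM to 25000 nM.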

Compound 3, half-maximal inhibitory concentration: 9000 nM
For compound 3 the middle estimate is 1.1-fold (0.05 log units) below the measured one; the measured number falls inside the stated range.
By their numbers in this assay, from the lowest: compounds 2 and 3 (each within the scatter of the next); then compound 1.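

In this assay, nitro in place of methoxy on an aromatic carbon, para to a large group, gives a 4.4-fold lower number from compound 1 to compound 3 (0.65 log units; beyond the scatter). The earlier step exchanged 4-methoxyphenyl for 3-cyanophenyl and so changed both the group and its place on the ring; here the place is held and the number still falls, so the drop does not depend on moving the group. The compounds shown leave open how an amine or a hydroxyl at this same place would read, and whether a nitro placed as the nitrile is in compound 2 would read differently. Nothing measured here explains this step.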